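Triazolylmethyl amide series: aryl swap on the triazole nitrogen

This account rests on a few compounds, and the source may have more. Where it says the series, first, only, none or still open, it means among the compounds named here.

compound 1 `N#CC1=C(N)Oc2c(c3nc4ccccc4nc3c3ccccc23)C12C(=O)N(Cc1cnnn1-c1cccc(Cl)c1)c1ccccc12`; in a functional assay on A549 cells (Homo sapiens) for antiproliferative activity, read by MTT assay, with a stated time of 48 h (a higher number here means a weaker inhibitor, a lower number a stronger inhibitor), compound 1 gives 32600 nM.
compound 2 `CC(=O)Nc1ccc(-n2nncc2CN2C(=O)C3(C(C#N)=C(N)Oc4c3c3nc5ccccc5nc3c3ccccc43)c3ccccc32)cc1`; in this assay compound 2 gives only a limit, > 50000 nM.

Compound 2 sits at the limit of this assay, as the limit of > 50000 nM in this assay, at which 1 of the 2 values shown sits, notes, so only a floor is known for it. For the measured compounds named here, the single measured step, an at least 1.5-fold higher number from compound 1 to compound 2 (0.18 log units; that floor lies within the scatter), replaced 3-chlorophenyl with 4-acetamidophenyl on the aromatic nitrogen and weakened inhibition, its floor within the scatter.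

Compound 3 `Cc1ccc(C)c(-n2nncc2CN2C(=O)C3(C(C#N)=C(N)Oc4c3c3nc5ccccc5nc3c3ccccc43)c3ccccc32)c1` carries the change (2,5-dimethylphenyl in place of 4-acetamidophenyl on an aromatic nitrogen). The group that leaves brings one hydrogen-bond donor and one hydrogen-bond acceptor; the group that enters brings none, which in that count resembles the 3-chlorophenyl of compound 1. Only an at least 1.5-fold higher number from compound 1 to compound 2 (0.18 log units; that floor lies within the scatter) bears on this step; read in reverse it suggests a small gain in this assay, within or just beyond the scatter. Compound 3 is therefore expected near 38000 nM, between 18000 nM and 90000 nM. The expected step is an at least 1.3-fold lower number from compound 2 to compound 3 (0.11 log units; that floor lies within the scatter).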

Compound 3, half-maximal inhibitory concentration: > 50000 nM
Compound 3: only a limit was reported (the forecaster's own chance of this, stated with the estimate: 40%); at least 1.3-fold (0.11 log units) between middle value and limit.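

In this assay compound 3 also ends at a limit of the assay, not a number: the limit of > 50000 nM in this assay, at which 2 of the 3 values shown sit. Having no hydrogen-bond donors or acceptors on the aryl group therefore does not by itself keep a measurable value at this aromatic nitrogen, since compound 1 and compound 3 share that count but only compound 1 gives a number, and the 3-chlorophenyl to 2,5-dimethylphenyl change gives an at least 1.5-fold higher number from compound 1 to compound 3 (0.18 log units; that floor lies within the scatter). The step between compound 2 and compound 3 cannot be read, as both values are limits.

From the compounds shown here alone, how far the value lies past the limit for compound 2 and compound 3 remains unknown. Also open, going by these compounds, is whether a phenyl ring bearing an amine or a carboxylic acid, or a longer alkyl chain in place of the aryl ring, would shift the value in this assay.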